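The source may report more compounds than this note shows. Statements on the series, on what has been measured and on what is new or still open speak of the compounds shown alone.

Compound 1, `CCOc1nc(Cl)cc(NC(=O)NCc2cc(C)c(-c3cn(C)nc3C(F)(F)F)nn2)c1C`: 32000 nM
Compound 2, `CCOc1nc(C#N)cc(NC(=O)NCc2cc(C)c(-c3cn(C)nc3C(F)(F)F)nn2)c1C`: 17000 nM
Compound 3, `CCOc1nc(C)cc(NC(=O)NCc2cc(C)c(-c3cn(C)nc3C(F)(F)F)nn2)c1Cl`: 49000 nM

Of the compounds shown here, three have been measured in a functional assay on HFL1 cells for antagonist activity at sphingosine 1-phosphate receptor 2 (Homo sapiens), read by ELISA, with a stated time of 24 h, in the presence of a further agent that is not named here; a higher number here means a weaker inhibitor, a lower number a stronger inhibitor. Compound 1 and compound 2 differ by cyano in place of chloro on an aromatic carbon, and the step was a 1.9-fold lower number from compound 1 to compound 2 (0.27 log units; within the scatter). Compound 1 and compound 3 are built from the same atoms joined differently, the difference being (3-chloro-2-ethoxy-6-methylpyridin-4-yl in place of 6-chloro-2-ethoxy-3-methylpyridin-4-yl on an amide-type nitrogen); the step was a 1.5-fold higher number from compound 1 to compound 3 (0.19 log units; within the scatter). Compound 3 carries the highest of the three numbers, but its gap to compound 1 lies within the scatter, so no order between them can be claimed; only its gap to compound 2 lies beyond the scatter.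

Compound 4, `CCOc1nc(C)cc(NC(=O)NCc2cc(C)c(-c3cn(C)nc3C(F)(F)F)nn2)c1C#N`, has not yet been measured. It differs from compound 3 by cyano in place of chloro on an aromatic carbon. This is the same kind of change that turned compound 1 into compound 2, and it occurs twice among the compounds shown, but the surroundings differ: in compound 1 the chloro sits "next to the ring nitrogen; meta to a large group; meta to an ethoxy group", whereas in compound 3 it sits "ortho to a large group; ortho to an ethoxy group; two atoms from the ring nitrogen". For the measured compounds named here, the step from compound 3 to compound 4 in this assay is expected to be a 1.6-fold lower number from compound 3 to compound 4 (0.21 log units; within the scatter), modest and of uncertain direction, because the only earlier instance of this kind of change gave a 1.9-fold lower number from compound 1 to compound 2 (0.27 log units; within the scatter). Compound 4 is therefore estimated to give 30000 nM, most likely between 12000 nM and 70000 nM.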

Compound 4, half-maximal inhibitory concentration: > 30000000 nM
Compound 4: only a limit was reported (the forecaster's own chance of this, stated with the estimate: 20%); at least 1000-fold (3.00 log units) between middle value and limit.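

In this assay, cyano in place of chloro on an aromatic carbon, at the place ortho to a large group and ortho to an ethoxy group, gave an at least 610-fold higher number from compound 3 to compound 4 (2.78 log units; beyond the scatter). The same change therefore did not carry over from one core to the other in this series, and the two instances stand apart by more than the scatter allows: the same change on two cores in this assay, a 1.9-fold lower number (0.27 log units; within the scatter) from compound 1 to compound 2 and an at least 610-fold higher number (2.78 log units; beyond the scatter) from compound 3 to compound 4, at least 1100-fold (3.06 log units) apart, beyond the scatter of two such steps

Compound 4 is known only through a limit, which is not a number, and the comparison shows neither the true size of its step nor what in the two surroundings sets the steps apart: the limit of > 30000000 nM in this assay, at which 1 of the 4 values shown sits.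

The compounds shown leave open whether the steep loss seen with compound 4 belongs to cyano alone at this place, or would also appear with another small group there, such as fluoro, methoxy or an amine. They also leave open whether a carboxylic acid or a primary amide in the same place, ortho to a large group and ortho to an ethoxy group, would stay near compound 3 or fall to a limit as compound 4 did.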